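Shrinking a ring on the quaternary nitrogen of compound 2

The source may hold more compounds than are shown below. What is called first, only, known or untested is meant among the compounds shown, and "the series" means these compounds.

Of the compounds shown here, three sharing one core have been tested in a functional assay (strain AB) with Danio rerio as the target, read by microscopy, with a stated time of 1 h; a higher number here means that more compound is needed for the effect, a lower number that less compound is needed. Compound 1 `CC(C)(C)OC(=O)CCCN1CCc2c(sc(NC(=O)Nc3ccc(Cl)cc3)c2C(N)=O)C1` gives 560 nM. Compound 2 `C[N+]1(CC2CCC2)CCc2c(sc(NC(=O)Nc3ccc(Cl)cc3)c2C(N)=O)C1` gives 210 nM, the lowest of the two numbers, and compound 1 sits beyond the scatter above it. Compound 3 `CCN1CCc2c(sc(NC(=O)Nc3ccc(Cl)cc3)c2C(=O)c2nc(C)no2)C1` gives only a limit of the assay, > 25000 nM, as noted in the limit of > 25000 nM in this assay, at which 1 of the 3 values shown sits.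

Compound 4 `C[N+]1(CC2CC2)CCc2c(sc(NC(=O)Nc3ccc(Cl)cc3)c2C(N)=O)C1` is not yet measured. It differs from compound 2 in one place: cyclopropyl in place of cyclobutyl on a saturated chain carbon bound to an amine nitrogen in a ring. Such a small trim to the group on the charged nitrogen is expected to move this assay little, so the step from compound 2 to compound 4 is estimated at a 1.4-fold higher number from compound 2 to compound 4 (0.15 log units; within the scatter), within the scatter. Compound 4 is therefore expected to give about 300 nM, between 120 nM and 800 nM.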

Compound 4, half-maximal effective concentration: 360 nM
Estimate against measurement, compound 4: 1.2-fold (0.08 log units) below; the range from low to high includes it.
By their numbers in this assay, from the lowest: compounds 2, 4 and 1 (each within the scatter of the next, the first and the last beyond it). At a limit, above all of these: compound 3.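

Cyclopropyl in place of cyclobutyl on a saturated chain carbon bound to an amine nitrogen in a ring gives a 1.7-fold higher number from compound 2 to compound 4 (0.23 log units; within the scatter) in this assay and so does not move the number beyond the usual scatter. For the compounds shown here, this is the first direct comparison at this position, and it shows that going from cyclobutylmethyl to cyclopropylmethyl is tolerated here. Nothing in the available evidence bears on why the number holds.

The compounds shown leave open how a cyclopentyl ring or a longer open chain would read in this place. On these data alone, whether a carboxylic acid or an amine at the end of such a chain would keep the number also remains open.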